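The source may hold more compounds than are shown below. What is called first, only, known or untested is meant among the compounds shown, and "the series" means these compounds.

Working notes on the series. The three measured compounds share one core and differ only in the group attached to the carbonyl. In a functional assay on HCT-15 cells (Homo sapiens) for inhibition, read by sulforhodamine B assay, with a stated time of 48 h, tested at 10 uM (on this read-out higher numbers stand for a weaker effect at the one concentration tested and lower numbers for a stronger effect), compound 1 `COc1cc(Cl)cc(-c2nn(-c3cccc(NC(=O)Nc4cccc(C(F)(F)F)c4)c3)cc2-c2ccncc2)c1` gives 7.83%, compound 2 `COc1cc(Cl)cc(-c2nn(-c3cccc(NC(=O)Nc4ccc(Cl)c(C(F)(F)F)c4)c3)cc2-c2ccncc2)c1` gives 7.28% and compound 3 `COc1cc(Cl)cc(-c2nn(-c3cccc(NC(=O)c4cccc(C(F)(F)F)c4)c3)cc2-c2ccncc2)c1` gives 33.2%. Compound 2 stands at the lowest of the three numbers in this assay, but its gap to compound 1, a number 0.6 percentage points lower from compound 1 to compound 2 (within the scatter), is within the scatter, so no order between compound 1 and compound 2 is claimed. Among the compounds with values here, the only steps beyond the scatter are those to compound 3: a number 25.4 percentage points higher from compound 1 to compound 3 (beyond the scatter) and a number 25.9 percentage points higher from compound 2 to compound 3 (beyond the scatter), both modest and both from a change at the carbonyl carbon.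

Compound 4 `O=C(Nc1cccc(-n2cc(-c3ccncc3)c(-c3cc(O)cc(Cl)c3)n2)c1)Nc1ccc(Cl)c(C(F)(F)F)c1` is not yet measured in this assay. Within the data shown here, it differs from compound 2 by hydrogen in place of methyl on an oxygen on an aromatic ring, that is methoxy to hydroxy on the 3-chloro-5-methoxyphenyl ring, and none of the measured steps touches that oxygen; the three measured steps all concern the carbonyl side. Among the measured compounds shown here, no bearing step exists, so the expectation for compound 4 is that the number stays close to that of compound 2, with a step of a number 2.7 percentage points higher from compound 2 to compound 4 (within the scatter) that is estimated not to exceed the scatter. Compound 4 is therefore expected to give 10% in this assay, within a range from 3% to 30%.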

Compound 4, a percentage reported as activity, at one concentration (the size of the read-out at that concentration, not a potency): 5.79%
Compound 4: middle estimate off by 4.2 percentage points, on the high side; the range from low to high includes it.
By their numbers in this assay, from the lowest: compounds 4, 2 and 1 (each within the scatter of the next); then compound 3.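

Methoxy to hydroxy on the 3-chloro-5-methoxyphenyl ring is the first change shown away from the carbonyl side of the series, and in this assay it gives a number 1.5 percentage points lower from compound 2 to compound 4 (within the scatter). Within the data shown here, at this oxygen, then, hydrogen can stand in place of methyl without a step beyond the scatter, at the one concentration tested and with the (4-chloro-3-(trifluoromethyl)phenyl)amino group on the carbonyl carbon; this rests on a single pair, and the only steps beyond the scatter remain those at the carbonyl carbon. Nothing at hand bears on why this exchange leaves the read-out within the scatter.

The compounds shown leave open whether a group larger than methyl on this oxygen, such as a longer chain ending in an amine or a carboxylic acid, would keep the number in the same range. Also open, going by these compounds, is whether the same exchange reads alike with 3-(trifluoromethyl)phenyl directly on the carbonyl carbon, and a read-out at one concentration cannot tell whether compound 2 and compound 4 differ in potency.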